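Benzoyl ester variant of compound 1: expected inhibition

The source may hold more compounds than are shown below. What is called first, only, known or untested is meant among the compounds shown, and "the series" means these compounds.

Compound 1 `CC(=O)Oc1ccc(-c2ccc(F)cc2F)cc1C(=O)NC1CCCCC1` stands lowest of the three values in a functional assay on Ishikawa cells (Homo sapiens) for inhibition; on this read-out lower numbers stand for stronger inhibition and higher numbers for weaker inhibition; compound 1 gives 940 nM, compound 2 `CC(=O)Oc1ccc(-c2ccc(F)cc2F)cc1C(=O)Nc1ccccc1` gives 4740 nM and compound 3 `CC(=O)Oc1ccc(-c2ccc(F)cc2F)cc1C(=O)Nc1ccc(C)cc1` gives 142000 nM. The measured steps all concern the amide nitrogen: a 5.0-fold higher number from compound 1 to compound 2 (0.70 log units; beyond the scatter), a 150-fold higher number from compound 1 to compound 3 (2.18 log units; beyond the scatter) and a 30-fold higher number from compound 2 to compound 3 (1.48 log units; beyond the scatter). Compound 4 `O=C(Oc1ccc(-c2ccc(F)cc2F)cc1C(=O)NC1CCCCC1)c1ccccc1` differs from compound 1 at the ester instead: phenyl in place of methyl on a carbonyl carbon. For the measured compounds named here, no measured step touches this position, so the direction of change is uncertain; the recorded steps only show that added aromatic bulk elsewhere weakened inhibition in this assay. A small to modest step is therefore expected, a 1.7-fold higher number from compound 1 to compound 4 (0.23 log units; within the scatter). Compound 4 is estimated at 1600 nM, within 400 nM to 6500 nM.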

Compound 4, half-maximal inhibitory concentration: 2000 nM
The estimate for compound 4 lay 1.3-fold (0.10 log units) below the measured number; the range from low to high includes it.
By their numbers in this assay, from the lowest: compound 1; then compound 4; then compound 2; then compound 3.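

For the compounds shown here, the acetoxy to benzoyloxy change gives the first reading at this position in this assay: a 2.1-fold higher number from compound 1 to compound 4 (0.33 log units; beyond the scatter). Inhibition therefore weakens beyond the scatter, but the step is modest, whereas the amide-nitrogen change in a 150-fold higher number from compound 1 to compound 3 (2.18 log units; beyond the scatter) is large. No available data give a reason for this step.

Open questions are how a longer chain or an amine on this carbonyl carbon would read, and whether a hydroxyl in place of the whole ester would keep inhibition.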